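This account rests on a few compounds, and the source may have more. Where it says the series, first, only, none or still open, it means among the compounds named here.

Measured in a functional assay on HepG2 cells (Homo sapiens) for antiproliferative activity, read by MTT assay, with a stated time of 24 h; on this read-out lower numbers stand for stronger inhibition and higher numbers for weaker inhibition:
- compound 1 `Cc1ccc(-c2nn(-c3ccccc3)cc2-c2nc3ccccc3n2S(=O)(=O)c2ccccc2)cc1`: 960 nM
- compound 2 `Cc1ccc(-c2nn(-c3ccccc3)cc2-c2nc3ccccc3n2S(=O)(=O)c2ccc(Cl)cc2)cc1`: 5520 nM
- compound 3 `O=S(=O)(c1ccccc1)n1c(-c2cn(-c3ccccc3)nc2-c2ccc(F)cc2)nc2ccccc21`: 720 nM

Compound 3, at 720 nM, sits at the low end of this small set alongside compound 1, and the two cannot be told apart: a 1.3-fold lower number from compound 1 to compound 3 (0.12 log units; within the scatter). Compound 2, at 5520 nM, gives a higher number than either.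

Compound 4 `COc1ccc(S(=O)(=O)n2c(-c3cn(-c4ccccc4)nc3-c3ccc(F)cc3)nc3ccccc32)cc1` has methoxy in place of hydrogen on an aromatic carbon of the phenylsulfonyl group, para to a large group: methoxy in place of hydrogen on an aromatic carbon. The closest measured change also replaces hydrogen on that group, with chloro, and gives a 5.8-fold higher number from compound 1 to compound 2 (0.76 log units; beyond the scatter). Within the data shown here, the fluoro for methyl change lies elsewhere in the molecule, so it shows only that the two starting compounds are comparable. Among the measured compounds shown here, no methoxy compound has been measured, and the chloro change is a single precedent, so a rise in the same direction but of smaller size is expected. The expected change is a 2.1-fold higher number from compound 3 to compound 4 (0.32 log units; beyond the scatter). Compound 4 is estimated at 1500 nM, with an expected range of 450 nM to 5000 nM.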

Compound 4, half-maximal inhibitory concentration: 470 nM
For compound 4 the middle estimate is 3.2-fold (0.50 log units) above the measured one; the range from low to high includes it.
By their numbers in this assay, from the lowest: compounds 4, 3 and 1 (each within the scatter of the next, the first and the last beyond it); then compound 2.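

In this assay, methoxy at this position of the phenylsulfonyl group, para to a large group, leaves the number within the scatter: a 1.5-fold lower number from compound 3 to compound 4 (0.19 log units; within the scatter). Compound 3 and compound 4 therefore cannot be told apart, so this position accepts methoxy in place of hydrogen with no measurable loss, and the rise seen with chloro, a 5.8-fold higher number from compound 1 to compound 2 (0.76 log units; beyond the scatter), is not shared by every replacement of hydrogen here. The two steps start from different compounds, and nothing available accounts for the difference between them.

As far as these compounds go, whether chloro would give the same rise on compound 3 remains open. So does the outcome with an amine, a carboxylic acid or a longer chain such as butoxy at this position.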